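Compound 2 to compound 3: one aromatic group exchanged

The source may hold more compounds than are shown below. What is called first, only, known or untested is meant among the compounds shown, and "the series" means these compounds.

Of the compounds shown here, two built on a shared core have been tested in a functional assay on MCF7 cells (Homo sapiens) for cytotoxicity, read by MTT assay, with a stated time of 72 h; a lower number here means a stronger inhibitor, a higher number a weaker inhibitor. Compound 1 `COc1ccc(/C=C2\CCC/C(=C\c3ccccc3Cl)C2=O)cc1OC` gives 10400 nM, and compound 2 `COc1ccc(/C=C2\CCC/C(=C\c3ccc(OC)c(OC)c3)C2=O)cc1` gives 7800 nM. These two numbers lie within the scatter of each other, so the pair cannot be ranked. Compound 3 `COc1ccc(/C=C2\CCC/C(=C\c3ccc(O)c(Cl)c3)C2=O)cc1OC` has not yet been measured. It differs from compound 2 in one place, on a double-bonded chain carbon bound to a double-bonded ring carbon, where 3-chloro-4-hydroxyphenyl stands in place of 4-methoxyphenyl (3-chloro-4-hydroxyphenyl in place of 4-methoxyphenyl on a double-bonded chain carbon bound to a double-bonded ring carbon). For the measured compounds named here, only one measured step concerns that place. It is a 1.3-fold lower number from compound 1 to compound 2 (0.12 log units; within the scatter), which stays within the scatter although 4-methoxyphenyl replaced 2-chlorophenyl there. Going by the values given here, this is thin evidence, as it is a single step and no measured compound carries a hydroxy group. With that one step as the guide, no shift beyond the scatter is expected in this assay. The expected change is a 1.1-fold lower number from compound 2 to compound 3 (0.05 log units; within the scatter), an estimate with a wide margin. For compound 3 the estimated value is 7000 nM, with an expected range from 2500 nM to 20000 nM.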

Compound 3, half-maximal inhibitory concentration: 12300 nM
For compound 3 the middle estimate is 1.8-fold (0.24 log units) below the measured one; the measured number falls inside the stated range.
By their numbers in this assay, from the lowest: compounds 2, 1 and 3 (each within the scatter of the next).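

In this assay, a third kind of substituted phenyl ring on the double-bonded chain carbon bound to a double-bonded ring carbon still gives no step beyond the scatter, whether 3-chloro-4-hydroxyphenyl is set against 4-methoxyphenyl (a 1.6-fold higher number from compound 2 to compound 3 (0.20 log units; within the scatter)) or against 2-chlorophenyl (a 1.2-fold higher number from compound 1 to compound 3 (0.07 log units; within the scatter)). For the compounds shown here, this exchange also brings in the first hydroxy group and, with it, a hydrogen-bond donor that 4-methoxyphenyl lacks, yet these three compounds cannot be ranked in this assay, so at this place neither that hydroxy group nor the chlorine of the new group shows any effect that can be read beyond the scatter. No other measurement here explains why the three groups give readings so close together.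

All three groups at this place are phenyl rings carrying only chloro, methoxy or hydroxy substituents, so the compounds shown do not reveal how far the number can move there. Going by these compounds, an amine, a carboxylic acid or a longer chain at this place might shift it beyond the scatter or might leave it unchanged, and that question remains open.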